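An Added Methoxycarbonyl and Its Expected Solubility

This account rests on a few compounds, and the source may have more. Where it says the series, first, only, none or still open, it means among the compounds named here.

Of the compounds shown here, three have been measured in a physicochemical assay for solubility; on this read-out lower numbers stand for lower solubility and higher numbers for higher solubility. Compound 1 `O=C(Nc1ccccc1)c1cc2cc([N+](=O)[O-])ccc2s1` gives 10 ug/mL in this assay and stands second highest among the three numbers. Compound 2 `NC(=O)c1ccccc1NC(=O)c1cc2cc([N+](=O)[O-])ccc2o1` gives 5 ug/mL, a number within the scatter of compound 1. Compound 3 `NCc1ccccc1NC(=O)c1cccc2ccccc12` gives 25 ug/mL, which lies beyond the scatter above compound 1. No two of these compounds differ in a single place, so no measured step exists. Compound 4 `COC(=O)c1ccc(NC(=O)c2cc3cc([N+](=O)[O-])ccc3s2)cc1` differs from compound 1 by methoxycarbonyl in place of hydrogen on an aromatic carbon. Without a comparable step to lean on, a downward step of modest size, somewhat beyond the scatter, is expected in this assay. Compound 4 is estimated at 4 ug/mL, between 1.5 ug/mL and 12 ug/mL. That estimate corresponds to an expected step of a 2.5-fold lower number from compound 1 to compound 4 (0.40 log units; beyond the scatter).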

Compound 4, solubility: 10 ug/mL
For compound 4 the middle estimate is 2.5-fold (0.40 log units) below the measured one, within the range that was stated.
By their numbers in this assay, from the lowest: compounds 2, 1 and 4 (each within the scatter of the next); then compound 3.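

In this assay, methoxycarbonyl in place of hydrogen on an aromatic carbon, para to a large group, gives no change at the digits printed from compound 1 to compound 4 (within the scatter) and is the only single-place step among these compounds. At this position, 4 heavy atoms enter without moving the read-out beyond the scatter. Nothing measured here offers an explanation for this result. Going by these compounds, whether an amine or a carboxylic acid in the same place would give a step beyond the scatter remains open. So does the step for methoxycarbonyl elsewhere on this ring.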